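The source may report more compounds than this note shows. Statements on the series, on what has been measured and on what is new or still open speak of the compounds shown alone.

Measured so far:
Compound 1 `CC(O)(CSc1ccccc1C(F)(F)F)C(=O)Nc1cc(C(F)(F)F)cc(C(F)(F)F)c1`: 3570 nM
Compound 2 `CC1(C)C(=O)N(c2ccc(C#N)c(C(F)(F)F)c2)C(=S)N1c1cc(C(F)(F)F)cc(C(F)(F)F)c1`: "nd(insoluble)" (no result reported)

In a functional assay on LNCaP cells (Homo sapiens) for antiproliferative activity, read by fluorescence and propidium iodide staining, with a stated time of 96 h (on this read-out higher numbers stand for weaker inhibition and lower numbers for stronger inhibition), compound 1 gives 3570 nM. Compound 2 gives "nd(insoluble)" (no result reported) in this assay, so it has no number, since it was reported insoluble and could not be measured. Compound 3 `CC1(C)C(=O)N(c2ccc([N+](=O)[O-])c(C(F)(F)F)c2)C(=S)N1c1cc(C(F)(F)F)cc(C(F)(F)F)c1` differs from compound 2 by nitro in place of cyano on an aromatic carbon. Within the data shown here, with no measured pair showing this change and no number for compound 2, neither the size nor the direction of the step can be read from these data. Compound 3 is expected to give about 1500 nM, with a range from 300 nM to 8000 nM.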

Compound 3, half-maximal inhibitory concentration: 9930 nM
The estimate for compound 3 lay 6.6-fold (0.82 log units) below the measured number, outside the stated range (above it).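

No step can be read between compound 2 and compound 3 in this assay, as compound 2 has no number there. The compounds shown leave open how nitro in place of cyano changes inhibition, and no measured evidence bears on this result.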